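A methyl added to the chain of compound 1

The source may hold more compounds than are shown below. What is called first, only, known or untested is meant among the compounds shown, and "the series" means these compounds.

- compound 1 `CCCCCCCCC(CCO)n1cnc2c(N)ncnc21` gives 11600 nM
- compound 2 `CCCCCCCCC(CCO)n1cnc2c(N)nc(Cl)nc21` gives 21000 nM
- compound 3 `CCCCCCCCCC(CCO)n1cnc2c(N)ncnc21` is not yet measured

Going by the values given here, in a functional assay on HCT-116 cells (Homo sapiens) for antiproliferative activity, read by MTT assay, with a stated time of 48 h (a lower number here means a stronger inhibitor, a higher number a weaker inhibitor), compound 1 lies within the scatter of compound 2, its only measured neighbour. Compound 3 differs from compound 1 by methyl in place of hydrogen on a saturated chain carbon, nine bonds along the chain from an aromatic nitrogen in the chain. Among the compounds with values here, the only measured step of a 1.8-fold higher number from compound 1 to compound 2 (0.26 log units; within the scatter) is a chloro change on an aromatic carbon, so no measured step touches the chain, and it offers only a rough guide to size. No change beyond the scatter is therefore expected in this assay for this methyl. The expected step is a 1.2-fold lower number from compound 1 to compound 3 (0.09 log units; within the scatter) and its direction remains uncertain. Compound 3 is estimated at 9500 nM with an expected range from 4500 nM to 20000 nM for repeated measurements.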

Compound 3, half-maximal inhibitory concentration: 10500 nM
Beside the measured number, compound 3's estimate is 1.1-fold (0.04 log units) below it, and the stated range covers the measured number.
By their numbers in this assay, from the lowest: compounds 3, 1 and 2 (each within the scatter of the next).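

In this assay, going by these compounds alone, the first measured change to the chain itself, methyl in place of hydrogen on a saturated chain carbon, nine bonds along the chain from an aromatic nitrogen, gives a 1.1-fold lower number from compound 1 to compound 3 (0.04 log units; within the scatter). At this position, then, one extra carbon leaves the result within the usual scatter. No measurement here offers an explanation for this result.

As far as these compounds go, whether a much longer chain would behave the same way remains open. So does the effect of an amine or a carboxylic acid at this position.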